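Anilide acids: carboxy in place of nitro, stomach read-out

This account rests on a few compounds, and the source may have more. Where it says the series, first, only, none or still open, it means among the compounds named here.

Among the measured compounds shown here, compound 2 `O=C(O)c1cc(NC(=O)c2ccc([N+](=O)[O-])cc2)cc(C(=O)O)c1` stands at the high end of the numbers so far: in a functional assay on the whole organism (stomach) with Rattus norvegicus as the target (on this read-out higher numbers stand for an effect only at larger amounts of compound and lower numbers for an effect already at smaller amounts), compound 2 gives 61.1 mg/kg. Compound 1 `O=C(O)c1ccc(NC(=O)c2ccc(C(=O)O)cc2)cc1` lies within the scatter of it; in this assay compound 1 gives 54.3 mg/kg. For the measured compounds named here, compound 3 `N#Cc1ccc(C(=O)Nc2cccc(-c3nn[nH]n3)c2)cc1` is the only one separated from compound 2 beyond the scatter; in this assay compound 3 gives 21.4 mg/kg. Compound 4 `O=C(O)c1ccc(C(=O)Nc2cc(C(=O)O)cc(C(=O)O)c2)cc1` differs from compound 2 by carboxy in place of nitro on an aromatic carbon. Going by the values given here, no measured pair isolates this change. Compound 1 already carries carboxy in place of nitro and in this assay compound 1 gives 54.3 mg/kg, within the scatter of compound 2; on that basis no step beyond the scatter is expected. The step is estimated as a 1.1-fold lower number from compound 2 to compound 4 (0.05 log units; within the scatter). Compound 4 is expected to give 55 mg/kg in this assay, with a range from 28 mg/kg to 110 mg/kg.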

Compound 4, dose for 50% inhibition: 32.2 mg/kg
For compound 4 the middle estimate is 1.7-fold (0.23 log units) above the measured one; measured number inside the range.
By their numbers in this assay, from the lowest: compounds 3, 4, 1 and 2 (each within the scatter of the next, the first and the last beyond it).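

In this assay, carboxy in place of nitro on an aromatic carbon, para to a large group, now has a direct reading: a 1.9-fold lower number from compound 2 to compound 4 (0.28 log units; within the scatter). On this single pair, the position takes either group without a step beyond the scatter. Nothing on hand bears on what lies behind this result.

Open, on these data alone, is whether an amine or a methoxy group on this aromatic carbon would read differently from the nitro of compound 2 and the carboxy of compound 4. As far as these compounds go, whether the same change reads alike on another core also stays open.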